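Propyl for Methyl on the Amide Aryl Ring

The source may hold more compounds than are shown below. What is called first, only, known or untested is meant among the compounds shown, and "the series" means these compounds.

compound 1 `O=C(Nc1cccc(-c2oc3cc(-c4ccc(F)cc4)ccc3c(=O)c2O)c1)c1ccccc1F`: 10800 nM
compound 2 `Cc1cccc(C(=O)Nc2cccc(-c3oc4cc(-c5ccc(F)cc5)ccc4c(=O)c3O)c2)c1`: 8030 nM
compound 3 `CCCc1ccc(C(=O)Nc2cccc(-c3oc4cc(-c5ccc(F)cc5)ccc4c(=O)c3O)c2)cc1`: not yet measured

Of the compounds shown here, two have been tested in a functional assay on HCC1937 cells (Homo sapiens) for antiproliferative activity, read by CCK-8 assay, with a stated time of 72 h; a higher number here means a weaker inhibitor, a lower number a stronger inhibitor. Compound 1 gives 10800 nM, and compound 2 gives 8030 nM. For the measured compounds named here, compound 2 stands alongside compound 1 rather than apart from it: the only step between them, a 1.3-fold lower number from compound 1 to compound 2 (0.13 log units; within the scatter), lies within the scatter, so neither compound can be called the stronger of the pair.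

Compound 3 `CCCc1ccc(C(=O)Nc2cccc(-c3oc4cc(-c5ccc(F)cc5)ccc4c(=O)c3O)c2)cc1` is the next member. Its difference from compound 2 is 4-propylphenyl in place of 3-methylphenyl on a carbonyl carbon. Going by the values given here, this change sits in the same part of the molecule as the one step already measured, which also exchanged one aryl group for another on the carbonyl carbon and was within the scatter. Among the compounds with values here, with only that one step to draw on, and it showing no movement beyond the scatter, compound 3 is expected to land close to compound 2, with no clear direction favoured.

The step from compound 2 to compound 3 is estimated as a 1.1-fold lower number from compound 2 to compound 3 (0.06 log units; within the scatter). Compound 3 is therefore expected to give about 7000 nM, within a range from 3000 nM to 16000 nM.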

Compound 3, half-maximal inhibitory concentration: 15400 nM
The estimate for compound 3 lay 2.2-fold (0.34 log units) below the measured number; the measured number falls inside the stated range.
By their numbers in this assay, from the lowest: compounds 2, 1 and 3 (each within the scatter of the next).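

With 4-propylphenyl on the carbonyl carbon whose other neighbour is the amide-type nitrogen, the position now holds three different aryl groups, and the readings in this assay give a 1.9-fold higher number from compound 2 to compound 3 (0.28 log units; within the scatter) and a 1.4-fold higher number from compound 1 to compound 3 (0.15 log units; within the scatter) as the steps to the new compound. The single earlier step could speak only for one exchange, whereas all three pairs now lie within the scatter, so no aryl group shown here separates from the others, even with 4-propylphenyl bringing 9 heavy atoms where 3-methylphenyl has 7. The compounds shown offer nothing that could explain the spread of these numbers, and none is needed for steps of this size.

Compound 2 and compound 3 differ in both the chain and its place on the ring, so 4-methylphenyl or 3-propylphenyl on the same carbonyl carbon would be needed to tell those two changes apart. On these data alone, whether this position can move the number beyond the scatter at all also remains open, for instance with an amine or a carboxylic acid on the aryl ring, or with a chain longer than propyl.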